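A few compounds are considered here, and "the series" means these few. Any claim that something is new, unique, unknown or untested is made for them only; others in the source may bear on it.

In a functional assay on HT-29 cells (Homo sapiens) for antiproliferative activity, read by sulforhodamine B assay, with a stated time of 48 h (a higher number here means a weaker inhibitor, a lower number a stronger inhibitor), compound 1 `CCCCc1ccc(NS(=O)(=O)c2ccc(N3CCNC3=O)cc2)cc1` gives 610 nM and has the highest number of the three measured compounds. Compound 2 `O=C1NCCN1c1ccc(S(=O)(=O)Nc2cccc(Br)c2)cc1` at 77 nM and compound 3 `Cc1cc(C)cc(NS(=O)(=O)c2ccc(N3CCNC3=O)cc2)c1` at 82 nM both lie lower, each beyond the scatter from compound 1.

Compound 4 `CCCCOc1ccc(NS(=O)(=O)c2ccc(N3CCNC3=O)cc2)cc1` keeps the core of compound 1 and differs in one place: butoxy in place of butyl on an aromatic carbon with butoxy in place of butyl on an aromatic carbon, para to a large group. For the measured compounds named here, no measured pair tests this exchange directly.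

Going by the values given here, the one measured step is a 1.1-fold higher number from compound 2 to compound 3 (0.03 log units; within the scatter) on replacing 3-bromophenyl with 3,5-dimethylphenyl on a sulfonamide nitrogen, and it lies within the scatter. It is only a weak guide, as neither compound carries butyl or butoxy. Compound 1 at 610 nM therefore remains the main anchor for the expectation.

No step beyond the scatter is expected in this assay and no firm direction can be drawn from these data. The estimated step is a 1.4-fold lower number from compound 1 to compound 4 (0.13 log units; within the scatter) and stays within the scatter. The estimate for compound 4 is 450 nM with 140 nM to 1400 nM as its expected range.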

Compound 4, half-maximal inhibitory concentration: 630 nM
Compound 4: middle estimate off by 1.4-fold (0.15 log units), on the low side, within the range that was stated.
By their numbers in this assay, from the lowest: compounds 2 and 3 (each within the scatter of the next); then compounds 1 and 4 (each within the scatter of the next).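

Compound 4 gives the first direct test of this exchange: in this assay, butoxy in place of butyl on an aromatic carbon, para to a large group, gives a 1.0-fold higher number from compound 1 to compound 4 (0.01 log units; within the scatter). Compound 1 and compound 4 therefore cannot be told apart in this assay, so at this position the oxygen that butoxy brings, with its hydrogen-bond acceptor, leaves the result within the scatter of the butyl compound, and the two chains can be treated as interchangeable for this read-out only. No measurement offered here accounts for this match between the two compounds.

The compounds shown leave open whether the number at this position depends on the chain at all, as only butyl and butoxy are compared there, so a shorter chain such as methoxy, a longer chain such as hexyloxy, or a bare ring hydrogen would be needed to define the limits of this tolerance. Also open, going by these compounds, is whether an amine or a carboxylic acid on the same aromatic carbon would stay level with compound 1 and compound 4 or separate from them beyond the scatter.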